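This account rests on a few compounds, and the source may have more. Where it says the series, first, only, none or still open, it means among the compounds named here.

In a functional assay on MCF7 cells (Homo sapiens) for inhibition, with a stated time of 48 h (on this read-out lower numbers stand for stronger inhibition and higher numbers for weaker inhibition), compound 1 `COc1ccccc1Sc1c[nH]c2ccc(Cl)cc12` is reported only as a limit, > 2500 nM. Among the compounds with values here, compound 2 `COc1cc(Sc2c[nH]c3ccc(Br)cc23)cc(OC)c1OC` gives 43 nM, the only actual number so far. The single other result is that limit. Within the data shown here, no measured pair differs in one place only, so the change now in view has no measured step to lean on.

Compound 3 `COc1cc(Sc2c[nH]c3ccc([N+](=O)[O-])cc23)cc(OC)c1OC` carries nitro in place of bromo on an aromatic carbon, with the rest of compound 2 unchanged. In this assay the expected move is a moderate weakening rather than a collapse to the limit seen for compound 1. The estimated change a 2.8-fold higher number from compound 2 to compound 3 (0.45 log units; beyond the scatter) is expected to lie a little beyond the usual scatter. For compound 3 the estimate is 120 nM, with an expected range of 30 nM to 600 nM.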

Compound 3, half-maximal inhibitory concentration: 560 nM
Beside the measured number, compound 3's estimate is 4.7-fold (0.67 log units) below it; the measured number falls inside the stated range.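

Within the data shown here, the aromatic carbon carrying bromo in compound 2 proves sensitive to substitution: in this assay nitro in place of bromo gives a 13-fold higher number from compound 2 to compound 3 (1.11 log units; beyond the scatter) and this is the first single-place step, a large one. Compound 3 still gives an actual number, so this change weakens the read-out without reaching a limit. Compound 1 remains the only compound reported as a limit, which is not a number: the limit of > 2500 nM in this assay, at which 1 of the 3 values shown sits.

With only bromo and nitro compared at this carbon, a single step sets no trend and does not show which difference between the two groups matters. As far as these compounds go, whether an amine or a carboxylic acid at the same carbon would stay close to compound 2 or fall nearer compound 3 remains open.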